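The compounds below may be only part of what the source reports. "The series", "measured", "known", "first", "only" and "open" are said of these compounds alone.

Compound 1, `CC(C)(C)OC(=O)Nc1cccc(-c2csc(NC(=O)CCCCCC(=O)NO)n2)c1`, is the starting point. In an assay on isolated protein for inhibition of protein deacetylase HDAC6 (Homo sapiens), read by fluorescence, with a stated time of 17 h (a lower number here means a stronger inhibitor, a higher number a weaker inhibitor), compound 1 gives < 0.17 nM, which is a limit of the assay and not a number. Among the three measured values it is the only one sitting at the limit of < 0.17 nM in this assay, at which 1 of the 3 values shown sits. Compound 4, `Nc1cccc(-c2csc(NC(=O)CCCCCC(=O)NO)n2)c1`, differs from compound 1 in one place: hydrogen in place of tert-butoxycarbonyl on a nitrogen on an aromatic ring. Within the data shown here, two measured steps bear on this change. Compound 3, `CC(C)(C)OC(=O)Nc1cccc(-c2csc(NC(=O)CCCCCC(=O)Nc3ccccc3N)n2)c1`, carries 2-aminophenyl in place of hydroxy on the amide-type nitrogen, and in this assay compound 3 gives 1500 nM; the corresponding move is an at least 8800-fold higher number from compound 1 to compound 3 (3.94 log units; beyond the scatter). Compound 2, `CC(=O)Nc1cccc(-c2csc(NC(=O)CCCCCC(=O)Nc3ccccc3N)n2)c1`, carries methyl in place of tert-butoxy on the carbonyl carbon of that same nitrogen, and in this assay compound 2 gives 11200 nM; the move is a 7.5-fold lower number from compound 2 to compound 3 (0.87 log units; beyond the scatter). Only the second step alters the substituent on the aromatic nitrogen, and it was modest, though it ran toward tert-butoxycarbonyl and among compounds bearing 2-aminophenyl. A modest weakening is therefore expected, with the step estimated as an at least 5.8-fold higher number from compound 1 to compound 4 (0.76 log units; beyond the scatter). Compound 4 is expected to give 1 nM, within a range from 0.1 nM to 10 nM.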

Compound 4, half-maximal inhibitory concentration: 3.3 nM
For compound 4 the middle estimate is 3.3-fold (0.52 log units) below the measured one; low and high end bracket the measured number.
By their numbers in this assay, from the lowest: compound 4; then compound 3; then compound 2. At a limit, below all of these: compound 1.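

With hydroxy on the amide-type nitrogen, this assay gives a direct reading of this change on a nitrogen on an aromatic ring: an at least 19-fold higher number from compound 1 to compound 4 (1.28 log units; beyond the scatter). The only earlier reading at this nitrogen, a 7.5-fold lower number from compound 2 to compound 3 (0.87 log units; beyond the scatter), was modest and came from compounds bearing 2-aminophenyl, so the lower number has now gone with tert-butoxycarbonyl in both listed pairs, and the new step is printed as large. Its true size stays unknown, as compound 1 stands at a limit of the assay and not at a number: the limit of < 0.17 nM in this assay, at which 1 of the 4 values shown sits.

The compounds shown leave open where acetyl on that nitrogen would fall with hydroxy on the amide-type nitrogen, and how the free amino group would read with 2-aminophenyl there. They also leave open how a dimethylamino group or a urea at the same place would read in this assay.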